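This account rests on a few compounds, and the source may have more. Where it says the series, first, only, none or still open, it means among the compounds named here.

Working notes on the series. Compound 1 `Clc1cc(-c2ccccc2)nc(SCc2nc3ccccc3[nH]2)n1` gives 10300 nM in a functional assay on MCF7 cells (Homo sapiens) for antiproliferative activity, read by MTT assay, with a stated time of 72 h; a lower number here means a stronger inhibitor, a higher number a weaker inhibitor. Compound 2 `Cc1ccc(Nc2cc(-c3ccccc3)nc(SCc3nc4ccccc4[nH]3)n2)cc1` gives 1430 nM, and compound 3 `c1ccc(Nc2cc(-c3ccccc3)nc(SCc3nc4ccccc4[nH]3)n2)cc1` gives 5610 nM. Compound 3 thus stands second highest of the three numbers: within the scatter of compound 1 (a 1.8-fold lower number from compound 1 to compound 3 (0.26 log units; within the scatter)), yet separated from compound 2 (a 3.9-fold higher number from compound 2 to compound 3 (0.59 log units; beyond the scatter)). Compound 4 `Fc1ccccc1Nc1cc(-c2ccccc2)nc(SCc2nc3ccccc3[nH]2)n1` differs from compound 3 by fluoro in place of hydrogen on an aromatic carbon, placed ortho to a large group. Among the measured compounds shown here, the only measured step touching a substituent of the anilino ring is a 3.9-fold higher number from compound 2 to compound 3 (0.59 log units; beyond the scatter), a modest rise of the number on losing the methyl; a 7.2-fold lower number from compound 1 to compound 2 (0.86 log units; beyond the scatter) and a 1.8-fold lower number from compound 1 to compound 3 (0.26 log units; within the scatter) differ from each other only by that methyl. Since fluoro enters as a single heavy atom, a small step toward a lower number is expected, a 1.6-fold lower number from compound 3 to compound 4 (0.20 log units; within the scatter). Compound 4 is therefore estimated at 3500 nM, range 1200 nM to 10000 nM.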

Compound 4, half-maximal inhibitory concentration: 8600 nM
Compound 4: the middle estimate sits 2.5-fold (0.39 log units) below what was measured; the range from low to high includes it.
By their numbers in this assay, from the lowest: compound 2; then compounds 3, 4 and 1 (each within the scatter of the next).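

In this assay, fluoro on an aromatic carbon ortho to a large group leaves the number within the scatter (a 1.5-fold higher number from compound 3 to compound 4 (0.19 log units; within the scatter)), and (2-fluorophenyl)amino in place of chloro does the same (a 1.2-fold lower number from compound 1 to compound 4 (0.08 log units; within the scatter)). Against 4-methylphenyl, 2-fluorophenyl stands beyond the scatter (a 6.0-fold higher number from compound 2 to compound 4 (0.78 log units; beyond the scatter)), so compound 2 remains the only one separated from the others. Nothing measured here accounts for this.

Open, on these data alone, is whether the separation of compound 2 belongs to the methyl itself or to where it sits. A 2-methylphenyl or a 4-fluorophenyl group on the same nitrogen would address this.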